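The source may report more compounds than this note shows. Statements on the series, on what has been measured and on what is new or still open speak of the compounds shown alone.

Measured so far in an assay on blood for inhibition of C-X-C chemokine receptor type 3 (Homo sapiens), with a stated time of 30 min; on this read-out lower numbers stand for stronger inhibition and higher numbers for weaker inhibition:
compound 1, `CCOc1ncc(-c2nc(C(F)(F)F)sc2N2CCN(C(=O)Cn3cnc4ccccc43)[C@H](C)C2)cn1`, 192 nM
compound 2, `CCOc1ncc(-c2nc(C(F)(F)F)sc2N2CCN(C(=O)Cn3ncc4cccnc43)[C@H](C)C2)cn1`, 372 nM
compound 3, `CCOc1ncc(-c2nc(C(F)(F)F)sc2N2CCN(C(=O)Cn3c(=O)oc4ccccc43)[C@H](C)C2)cn1`, 536 nM

Compound 3 carries the highest of the three numbers in this assay. Its nearest neighbour is compound 2, a 1.4-fold higher number from compound 2 to compound 3 (0.16 log units; within the scatter), and its furthest is compound 1, a 2.8-fold higher number from compound 1 to compound 3 (0.45 log units; beyond the scatter); compound 1 and compound 2 themselves lie close, a 1.9-fold higher number from compound 1 to compound 2 (0.29 log units; within the scatter).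

Compound 4, `CCOc1ncc(-c2nc(C(F)(F)F)sc2N2CCN(C(=O)Cn3nccc3C)[C@H](C)C2)cn1`, differs from compound 3 in one place: a group of 6 heavy atoms (4 carbon, 2 nitrogen; one five-membered aromatic ring with 2 hetero atoms) in place of a group of 10 heavy atoms (7 carbon, 1 nitrogen, 2 oxygen; one five-membered aromatic ring with 2 hetero atoms, one six-membered aromatic ring of carbon only), on a saturated chain carbon bound to a carbonyl carbon. The three measured steps all exchange one group holding both a five-membered and a six-membered aromatic ring for another such group, and they moved the numbers only by modest amounts. Among the measured compounds shown here, none of them removes the six-membered aromatic ring altogether, so no measured step speaks directly to the change from compound 3 to compound 4. The measured steps suggest that changes at this saturated chain carbon shift the numbers only modestly, and on that footing the expected step from compound 3 to compound 4 is a 1.3-fold higher number from compound 3 to compound 4 (0.12 log units; within the scatter), leaning toward a higher number with wide uncertainty. Compound 4 is therefore estimated at 700 nM in this assay, expected to fall between 200 nM and 2500 nM.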

Compound 4, half-maximal inhibitory concentration: 289 nM
Beside the measured number, compound 4's estimate is 2.4-fold (0.38 log units) above it, within the range that was stated.
By their numbers in this assay, from the lowest: compounds 1, 4, 2 and 3 (each within the scatter of the next, the first and the last beyond it).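

In this assay, the 5-methyl-1H-pyrazol-1-yl group on a saturated chain carbon bound to a carbonyl carbon holds no six-membered aromatic ring, yet every step to it from a group holding both ring sizes stays within the scatter (a 1.9-fold lower number from compound 3 to compound 4 (0.27 log units; within the scatter)) (a 1.3-fold lower number from compound 2 to compound 4 (0.11 log units; within the scatter)) (a 1.5-fold higher number from compound 1 to compound 4 (0.18 log units; within the scatter)). Among these compounds, then, the six-membered aromatic ring is not required for a number in this range, and a group of 6 heavy atoms reads like the larger groups it replaces. Nothing on hand accounts for this result.

On these data alone, whether the methyl group of compound 4 matters remains open, as a plain 1H-pyrazol-1-yl group would be needed to tell. So does the response of this position to an amine or a carboxylic acid in place of the aromatic ring.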